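This account rests on a few compounds, and the source may have more. Where it says the series, first, only, none or still open, it means among the compounds named here.

Series notes. Compound 1 `Nc1ccc(S(=O)(=O)N2CCN(c3ncc(C(O)(C(F)(F)F)C(F)(F)F)cc3Br)CC2)cn1` gives 32 mL.min-1.g-1 in an ADME assay (liver) for metabolic stability, with Liver microsome (Rattus norvegicus) as the target, using microsomes and NADPH, with a stated time of 30 min, tested at 1 uM; on this read-out lower numbers stand for slow clearance and higher numbers for fast clearance. Compound 2 `COc1cc(C(O)(C(F)(F)F)C(F)(F)F)cnc1N1CCN(S(=O)(=O)c2ccc(N)nc2)CC1` reaches only the limit < 14 mL.min-1.g-1 in this assay. Compound 3 `Nc1ccc(S(=O)(=O)N2CCN(c3ncc(C(O)(C(F)(F)F)C(F)(F)F)cc3C#CCO)CC2)cn1` gives 65 mL.min-1.g-1 in this assay, the highest of the two numbers measured; the nearest shows a 2.0-fold higher number from compound 1 to compound 3 (0.31 log units; beyond the scatter), and against the limit there is an at least 4.6-fold higher number from compound 2 to compound 3 (0.66 log units; beyond the scatter). Compound 4 `Nc1ccc(S(=O)(=O)N2CCN(c3ncc(C(O)(C(F)(F)F)C(F)(F)F)cc3-c3cnccc3F)CC2)cn1` differs from compound 3 at the same aromatic carbon: 4-fluoropyridin-3-yl in place of 3-hydroxyprop-1-yn-1-yl on an aromatic carbon. Both measured exchanges at that carbon, bromo to 3-hydroxyprop-1-yn-1-yl and methoxy to 3-hydroxyprop-1-yn-1-yl, moved this assay beyond the scatter, so a shift is expected here as well, more likely downward given that compound 3 already sits at the top. Compound 4 is therefore estimated at 35 mL.min-1.g-1 (range 14 mL.min-1.g-1 to 90 mL.min-1.g-1), which is expected to be a 1.9-fold lower number from compound 3 to compound 4 (0.27 log units; within the scatter).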

Compound 4, intrinsic clearance in microsomes: 22 mL.min-1.g-1
For compound 4 the middle estimate is 1.6-fold (0.20 log units) above the measured one; low and high end bracket the measured number.
By their numbers in this assay, from the lowest: compounds 4 and 1 (each within the scatter of the next); then compound 3. At a limit, below all of these: compound 2.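

A ring at this position, 4-fluoropyridin-3-yl, gives a 3.0-fold lower number from compound 3 to compound 4 (0.47 log units; beyond the scatter) in this assay, so the high number of compound 3 does not carry over to every larger group on this aromatic carbon. Against bromo the same ring gives a 1.5-fold lower number from compound 1 to compound 4 (0.16 log units; within the scatter), which does not separate the two groups. With methoxy the comparison rests on a limit, and an at least 1.5-fold higher number from compound 2 to compound 4 (0.19 log units; that floor lies within the scatter) does not separate those groups either: the limit of < 14 mL.min-1.g-1 in this assay, at which 1 of the 4 values shown sits.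

Open, on these data alone, is whether the fluorine or the pyridine ring accounts for the step from the 3-hydroxyprop-1-yn-1-yl group. Also open, as far as these compounds go, is how a phenyl, a nitrile or an amine on this carbon would read in this assay.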